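This account rests on a few compounds, and the source may have more. Where it says the series, first, only, none or still open, it means among the compounds named here.

Values measured so far in a physicochemical assay for lipophilicity, at pH 7.4 (a lower number here means a more polar compound, a higher number a more lipophilic compound), for three compounds:

- compound 1 `Clc1ccc2c(c1-c1cn[nH]c1)CCC2c1ncc[nH]1` gives 2.6
- compound 2 `CS(=O)(=O)Cc1cccc2c1CCC2c1ncc[nH]1` gives 0.7
- compound 3 `COCc1cccc2c1CC[C@H]2c1ncc[nH]1` gives 1.8

Compound 2 has the lowest of these three numbers, which places it at the polar end of this small set. Compound 3 is its nearest neighbour on the scale and compound 1 its furthest, and both gaps lie beyond the usual scatter of repeated measurements.

The next compound, compound 4 `CCOCc1cccc2c1CCC2c1ncc[nH]1`, has not yet been measured. It is compound 2 with ethoxy in place of methylsulfonyl on a saturated chain carbon bound to an aromatic carbon in the structure. Cut one bond further out, the same difference reads (methylsulfonyl)methyl to ethoxymethyl.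

Among the measured compounds shown here, no pair of measured compounds shows this change on its own, so there is no direct step to borrow, and the size of the step is a judgement. A rise well beyond the scatter is expected. That expectation leans on the other two values, compound 3 at 1.8 and compound 1 at 2.6, which both stand higher than compound 2 does. The estimated change is a number 1.50 log units higher from compound 2 to compound 4 (beyond the scatter) on this scale. Compound 4 is therefore estimated at 2.2 with an expected range of 1.8 to 2.6 for its measurement.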

Compound 4, distribution coefficient: 2.1
Compound 4: the middle estimate sits 0.10 log units above what was measured, within the range that was stated.
By their numbers in this assay, from the lowest: compound 2; then compounds 3 and 4 (each within the scatter of the next); then compound 1.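

In this assay, putting ethoxy in place of methylsulfonyl on a saturated chain carbon bound to an aromatic carbon gives a number 1.40 log units higher from compound 2 to compound 4 (beyond the scatter), the first direct measure in this set of what one change at this place can do. The earlier compounds shown here offered no such single-change comparison, whereas this step shows that the group on this carbon can by itself move the number well beyond the scatter. The change replaces a group of 4 heavy atoms, with 2 hydrogen-bond acceptors and 2 double bonds outside aromatic rings, by one of 3 heavy atoms with 1 hydrogen-bond acceptor, but nothing measured here tells which of these differences accounts for the size of the step.

Going by these compounds, it remains open how other groups on this same carbon would compare, such as an amine, a carboxylic acid or a longer chain like butoxy. Also unknown is whether the same exchange would give a step of similar size on a differently substituted core, such as that of compound 1.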